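A few compounds are considered here, and "the series" means these few. Any claim that something is new, unique, unknown or untested is made for them only; others in the source may bear on it.

Of the compounds shown here, three have so far been measured in a functional assay on A549 cells (Homo sapiens) for inhibition, read by MTT assay, with a stated time of 72 h; on this read-out higher numbers stand for weaker inhibition of growth and lower numbers for stronger inhibition of growth. Compound 1 `CC(C)=CCC/C(C)=C/CC/C(C)=C/C(=O)NC(=N)N` gives 13700 nM. Compound 2 `CC(C)=CCC/C(C)=C/CC/C(C)=C/C(=O)NC(=N)NC(=O)C=C(C)C` gives 23400 nM, and compound 3 `CC(C)=CCC/C(C)=C/C(=O)NC(=N)NC(=O)C=C(C)C` gives 37400 nM. Compound 2 and compound 3 differ only in the length of the chain, as counted in hydrogen in place of 3-methylbut-2-en-1-yl on a saturated chain carbon bound to a double-bonded chain carbon, and this change gave a 1.6-fold higher number from compound 2 to compound 3 (0.20 log units; within the scatter). Compound 2 and compound 1 differ at the other end of the molecule, as counted in hydrogen in place of (2-methylprop-1-en-1-yl)carbonyl on an amine nitrogen, and this change gave a 1.7-fold lower number from compound 2 to compound 1 (0.23 log units; within the scatter).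

Compound 4 `CC(C)=CCC/C(C)=C/C(=O)NC(=N)N` has not yet been measured. It differs from compound 3 by hydrogen in place of (2-methylprop-1-en-1-yl)carbonyl on an amine nitrogen, which is the same change as that made between compound 2 and compound 1; the surroundings of the place are the same in both cases, so the two changes are the same, only made on the shorter core of compound 3. A step of a 1.7-fold lower number from compound 3 to compound 4 (0.23 log units; within the scatter) is expected, because the earlier step of a 1.7-fold lower number from compound 2 to compound 1 (0.23 log units; within the scatter) stayed within the scatter of repeated measurements. Compound 4 is therefore expected to give about 22000 nM in this assay, somewhere between 8000 nM and 60000 nM.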

Compound 4, concentration for 50% growth inhibition: 76500 nM
The estimate for compound 4 lay 3.5-fold (0.54 log units) below the measured number, outside the stated range (above it).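

Removing the (2-methylprop-1-en-1-yl)carbonyl group from the amine nitrogen did not behave the same way on the two cores in this assay, with a 2.0-fold higher number from compound 3 to compound 4 (0.31 log units; beyond the scatter) on the shorter core, and the two steps disagree: the same change on two cores in this assay, a 1.7-fold lower number (0.23 log units; within the scatter) from compound 2 to compound 1 and a 2.0-fold higher number (0.31 log units; beyond the scatter) from compound 3 to compound 4, 3.5-fold (0.54 log units) apart, beyond the scatter of two such steps Replacing 3-methylbut-2-en-1-yl with hydrogen also gave a different result once that group was gone, with a 5.6-fold higher number from compound 1 to compound 4 (0.75 log units; beyond the scatter), and again the two steps disagree: the same change on two cores in this assay, a 1.6-fold higher number (0.20 log units; within the scatter) from compound 2 to compound 3 and a 5.6-fold higher number (0.75 log units; beyond the scatter) from compound 1 to compound 4, 3.5-fold (0.54 log units) apart, beyond the scatter of two such steps This shows that, among these four compounds, a step seen on one core could not simply be carried to the other, but it does not show why, and both comparisons rest on the same four compounds, so it establishes no rule for the wider series.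

The compounds shown leave open whether the same mismatch would appear with another group on that nitrogen, such as acetyl or benzoyl, or with a longer chain. They also leave open whether it would hold in other cell lines.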